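The compounds below may be only part of what the source reports. "The series", "measured", "known", "first", "only" and "open" are said of these compounds alone.

Measured so far:
- compound 1, `c1ccc2c(c1)CN[C@@H](CN(CC[C@@H]1CCCNC1)[C@H]1CCCc3cccnc31)C2`: 28%
- compound 2, `c1cnc2c(c1)CN[C@H](CN(CCCN1CCNCC1)[C@H]1CCCc3cccnc31)C2`: 87%

In an ADME assay on microsomes from liver (Rattus norvegicus) for metabolic stability, read by LC-MS, with a stated time of 10 min, tested at 0.5 uM (a lower number here means that less of the compound is left, a higher number that more of the compound is left), compound 1 gives 28%, the lower of the two numbers recorded so far. Among the measured compounds shown here, compound 2 gives 87% in this assay, a gap well beyond the usual scatter; the two compounds differ in more than one place, so no single step is drawn between them, and only the two values themselves are noted.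

Compound 3, `c1ccc2c(c1)CN[C@@H](CN(CCCN1CCN(C3CC3)CC1)[C@H]1CCCc3cccnc31)C2`, has not been measured in this assay. It differs from compound 1 as (4-cyclopropylpiperazin-1-yl)methyl in place of piperidin-3-yl on a saturated chain carbon, two bonds along the chain from an amine nitrogen. For the measured compounds named here, with no measured step of the same kind available, the expectation rests loosely on the standing of compound 1 and compound 2, and the step from compound 1 to compound 3 is expected to be a moderate rise, a number 17 percentage points higher from compound 1 to compound 3 (beyond the scatter), though a step within the scatter cannot be ruled out. For compound 3 in this assay a value of about 45% is estimated, in the range 15% to 80%.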

Compound 3, percent of the compound remaining: 2%
Estimate against measurement, compound 3: 43 percentage points above; the measured number lies below the stated range.
By their numbers in this assay, from the lowest: compound 3; then compound 1; then compound 2.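

In this assay, (4-cyclopropylpiperazin-1-yl)methyl in place of piperidin-3-yl on a saturated chain carbon, two bonds along the chain from an amine nitrogen, gives a number 26 percentage points lower from compound 1 to compound 3 (beyond the scatter). Among the compounds shown here, this is the first one-place comparison, and it shows that a change at this position can move the read-out downward on the shared core. The entering group differs from the leaving one in its rings, its hydrogen-bond donors and acceptors and its size all at once, and no measurement here bears on the origin of the drop.

Open, going by these compounds, is how the step would read with a methyl group or a 2-hydroxyethyl group in place of the cyclopropyl of the entering group on the same core. Also open, on these data alone, is whether an unsubstituted piperazine at this position would give a step of similar size.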